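This account rests on a few compounds, and the source may have more. Where it says the series, first, only, none or still open, it means among the compounds named here.

Measured compounds:
- compound 1, `Cc1cccc(Cc2c(C#N)c3cc(O[C@H]4CC[C@@H](C(=O)O)CC4)ccc3n2C)c1`, in an assay on isolated protein for inhibition of Long-chain-fatty-acid--CoA ligase 1 (Homo sapiens), read by mass spectrometry, with a stated time of 90 min, in the presence of a further agent that is not named here (on this read-out lower numbers stand for stronger inhibition and higher numbers for weaker inhibition), gives 1900 nM
- compound 2, `Cc1ccc(Cc2nc3cc(O[C@H]4CC[C@@H](C(=O)O)CC4)ccc3n2C)cc1`, in this assay gives 150 nM

Of the two numbers in hand, compound 2 holds the lower one, and its gap to compound 1 lies beyond the usual scatter of this assay. Compound 3, `Cn1c(Cc2ccc3c(c2)OCC3)nc2cc(O[C@H]3CC[C@@H](C(=O)O)CC3)ccc21`, has not yet been measured in this assay. It differs from compound 2 in one place: a group of 9 heavy atoms (8 carbon, 1 oxygen; one five-membered non-aromatic ring with 1 hetero atom, one six-membered aromatic ring of carbon only) in place of a group of 7 heavy atoms (7 carbon; one six-membered aromatic ring of carbon only), on a saturated chain carbon bound to an aromatic carbon. For the measured compounds named here, no measured pair shows this exchange, so the expectation rests on compound 2 alone. The step of a 1.3-fold higher number from compound 2 to compound 3 (0.12 log units; within the scatter) is expected to be small, within the scatter, in either direction. Compound 3 is therefore estimated at 200 nM, with a range from 60 nM to 700 nM.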

Compound 3, half-maximal inhibitory concentration: 13 nM
Compound 3: middle estimate off by 15-fold (1.19 log units), on the high side, and the stated range ends above it.
By their numbers in this assay, from the lowest: compound 3; then compound 2; then compound 1.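

In this assay, the saturated chain carbon bound to an aromatic carbon proves highly sensitive to the group it carries: exchanging 4-methylphenyl for the group of 9 heavy atoms, with its five-membered non-aromatic ring with 1 hetero atom and its 1 hydrogen-bond acceptor, gives a 12-fold lower number from compound 2 to compound 3 (1.06 log units; beyond the scatter). For the compounds shown here, compound 1 and compound 2 differ in more than one place, so this is the first single-place change that can be read at this position. Nothing at hand gives a reason for the size of this step.

The compounds shown do not separate the contribution of the ring oxygen from that of the added ring as a whole. On these data alone, whether a simple methoxy group on the phenyl ring, or an all-carbon second ring, would give a similar number remains open, as does whether the step would carry over to the core of compound 1.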